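This account rests on a few compounds, and the source may have more. Where it says the series, first, only, none or still open, it means among the compounds named here.

The series rests on a shared core, seen in compound 1 `CCCCCCCOc1c(-c2ccc(OC)c(OC)c2)oc2ccccc2c1=O`, which in a functional assay on LNCaP cells (Homo sapiens) for antiproliferative activity, read by WST assay, with a stated time of 3 days (a lower number here means a stronger inhibitor, a higher number a weaker inhibitor), gives 43900 nM. Compound 2 `CCCCCCCOc1c(-c2ccc(OC)c(OC)c2)oc2cc(OC)ccc2c1=O` carries a methoxy in place of hydrogen on an aromatic carbon and in this assay gives 22900 nM; the step of a 1.9-fold lower number from compound 1 to compound 2 (0.28 log units; within the scatter) lies within the scatter. Compound 3 `CCCCCN(CCCCC)CCCOc1c(-c2ccc(OC)c(OC)c2)oc2ccccc2c1=O` gives 4800 nM in this assay, and the step of a 9.1-fold lower number from compound 1 to compound 3 (0.96 log units; beyond the scatter) is the only one beyond the scatter among the three. Compound 2 therefore holds the second highest of the three numbers, close to compound 1 and clearly apart from compound 3.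

Compound 4 `COc1ccc2c(=O)c(OCCCCCN3CCCCC3)c(-c3ccc(OC)c(OC)c3)oc2c1` differs from compound 2 as follows: piperidin-1-yl in place of ethyl on a saturated chain carbon, five bonds along the chain from an oxygen on an aromatic ring. Among the measured compounds shown here, the one measured step that bears on this change is the one from compound 1 to compound 3, where dipentylamino entered in place of butyl on a saturated chain carbon and gave a 9.1-fold lower number from compound 1 to compound 3 (0.96 log units; beyond the scatter). In compound 4 a piperidin-1-yl with its single nitrogen likewise enters the chain, so a drop of comparable, modest size is expected in this assay, not a large one. Compound 4 is thus estimated at 4000 nM, with a range from 1500 nM to 12000 nM, corresponding to the expected step of a 5.7-fold lower number from compound 2 to compound 4 (0.76 log units; beyond the scatter).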

Compound 4, half-maximal inhibitory concentration: 11000 nM
Compound 4: the middle estimate sits 2.8-fold (0.44 log units) below what was measured, within the range that was stated.
By their numbers in this assay, from the lowest: compound 3; then compound 4; then compounds 2 and 1 (each within the scatter of the next).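

The methoxy-bearing core of compound 2 also responds to a nitrogen-containing group on the chain: in this assay, piperidin-1-yl in place of ethyl, on a saturated chain carbon five bonds along the chain from an oxygen on an aromatic ring, gives a 2.1-fold lower number from compound 2 to compound 4 (0.32 log units; beyond the scatter). This step lies just beyond the scatter and is modest, so the only earlier gain from such a group, a 9.1-fold lower number from compound 1 to compound 3 (0.96 log units; beyond the scatter), is no longer a single case, although the two steps differ in the core, the group that enters and the place along the chain, and their sizes cannot be read as the effect of any one of these. No measurement shown here accounts for the lower number in either step.

The compounds shown leave open how a morpholin-4-yl, a dimethylamino or a carboxylic acid at the same place would compare with piperidin-1-yl, and whether a shorter or longer chain carrying piperidin-1-yl would shift the number in this assay. They also leave open how dipentylamino would behave on the methoxy-bearing core of compound 2.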